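A few compounds are considered here, and "the series" means these few. Any claim that something is new, unique, unknown or untested is made for them only; others in the source may bear on it.

In a functional assay on DU-145 cells (Homo sapiens), read by sulforhodamine B assay, with a stated time of 5 days (a higher number here means a weaker inhibitor of growth, a lower number a stronger inhibitor of growth), compound 1 `OC[C@H]1O[C@@H](n2cc(F)c3c(-c4ccco4)ncnc32)[C@H](O)[C@@H]1O` gives 5 nM, while compound 2 `OC[C@H]1O[C@@H](n2cc(F)c3c(-c4ccsc4)ncnc32)[C@H](O)[C@@H]1O` gives 66 nM, the higher of the two numbers. Compound 3 `OC[C@H]1O[C@@H](n2cc(F)c3c(-c4cc[nH]c4)ncnc32)[C@H](O)[C@@H]1O` differs from compound 2 in one group: 1H-pyrrol-3-yl in place of thiophen-3-yl on an aromatic carbon. Among the compounds with values here, the only measured step, a 13-fold higher number from compound 1 to compound 2 (1.12 log units; beyond the scatter), is large and shows that a swap at this place can move the number, but it involves a different pair of groups and sets no direction here. The expected step in this assay is therefore a 1.3-fold lower number from compound 2 to compound 3 (0.12 log units; within the scatter), with no shift expected beyond the scatter. Compound 3 is estimated at 50 nM, with an expected range of 10 nM to 300 nM.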

Compound 3, concentration for 50% growth inhibition: 10 nM
For compound 3 the middle estimate is 5.0-fold (0.70 log units) above the measured one, within the range that was stated.
By their numbers in this assay, from the lowest: compounds 1 and 3 (each within the scatter of the next); then compound 2.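

In this assay, within the data shown here, 1H-pyrrol-3-yl in place of thiophen-3-yl gives a 6.6-fold lower number from compound 2 to compound 3 (0.82 log units; beyond the scatter) and so shows a second swap at this aromatic carbon moving the number beyond the scatter, this time downward. 1H-pyrrol-3-yl in place of furan-2-yl gives a 2.0-fold higher number from compound 1 to compound 3 (0.30 log units; within the scatter) and thus no shift beyond the scatter, which leaves thiophen-3-yl as the one group standing apart among the three. Nothing available here accounts for these steps. The compounds shown leave open how furan-3-yl or thiophen-2-yl would compare on this carbon, and whether an amine there would keep the number low.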